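This account rests on a few compounds, and the source may have more. Where it says the series, first, only, none or still open, it means among the compounds named here.

Measured so far:
- compound 1 `Cc1cc(C(=O)Nc2ccc(Cl)cc2)ccc1N(CCN1CCCC1=O)C(=O)Nc1ccc(Cl)cc1` — 0.075 h
- compound 2 `Cc1cc(C(=O)Nc2ccc(F)cn2)ccc1N(CCN1CCCC1=O)C(=O)Nc1ccc(Cl)cc1` — 0.0517 h

In an ADME assay on microsomes from liver (Rattus norvegicus) for metabolic stability (a lower number here means that the compound disappears faster, a higher number that the compound lasts longer), compound 1 gives the higher of the two numbers, yet the gap to compound 2 is small: a 1.5-fold lower number from compound 1 to compound 2 (0.16 log units; within the scatter). Both half-lives are short, and on these numbers compound 1 and compound 2 cannot be set apart.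

Compound 3 `Cc1cc(C(=O)Nc2ccc(Cl)cc2)ccc1N(CC(=O)N1CCOCC1)C(=O)Nc1ccc(Cl)cc1` has not been measured in this assay. It differs from compound 1 by (morpholin-4-yl)carbonyl in place of (2-oxopyrrolidin-1-yl)methyl on a saturated chain carbon bound to an amide-type nitrogen. Within the data shown here, the only measured step, the one from compound 1 to compound 2, concerns the aryl group on the amide nitrogen and leaves the chain on the urea-type nitrogen untouched; it therefore says nothing direct about the change to compound 3. Among the measured compounds shown here, no measured pair alters the chain that carries the five-membered lactam or the morpholine amide, so the size and direction of the step are not anchored by data.

With nothing in the series pointing either way, compound 3 is expected to stay close to compound 1, with the step of a 1.1-fold higher number from compound 1 to compound 3 (0.03 log units; within the scatter) estimated to lie within the usual scatter. The estimate for compound 3 in this assay is 0.08 h, with a range from 0.03 h to 0.25 h.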

Compound 3, half-life: 0.765 h
Estimate against measurement, compound 3: 9.6-fold (0.98 log units) below; measured number outside the range, above it.
By their numbers in this assay, from the lowest: compounds 2 and 1 (each within the scatter of the next); then compound 3.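

In this assay, the saturated chain carbon bound to an amide-type nitrogen proves to be a place where the half-life can change strongly: a 10-fold higher number from compound 1 to compound 3 (1.01 log units; beyond the scatter). Among these compounds, the only earlier step, 5-fluoropyridin-2-yl in place of 4-chlorophenyl, gave no such separation: a 1.5-fold lower number from compound 1 to compound 2 (0.16 log units; within the scatter). The change itself, read one bond further out, is 2-(2-oxopyrrolidin-1-yl)ethyl to ((morpholin-4-yl)carbonyl)methyl, which replaces a five-membered non-aromatic ring with 1 hetero atom by a six-membered non-aromatic ring with 2 hetero atoms, and nothing available explains the size of this step.

The ring and the attachment of the carbonyl change together in this one step, so the compounds shown do not separate their contributions; a 2-(morpholin-4-yl)ethyl chain or a (pyrrolidin-1-yl)carbonyl group in the same place would tell the two apart. Also open, going by these compounds, is whether the higher number in this assay carries over to the core of compound 2, with its 5-fluoropyridin-2-yl group, when that core bears the (morpholin-4-yl)carbonyl group.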